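Fluoro to nitro on the methoxyphenyl ring

The compounds below may be only part of what the source reports. "The series", "measured", "known", "first", "only" and "open" are said of these compounds alone.

Among the compounds with values here, in a functional assay on MIA PaCa-2 cells (Homo sapiens) for antiproliferative activity, read by sulforhodamine B assay, with a stated time of 48 h (a higher number here means a weaker inhibitor, a lower number a stronger inhibitor), compound 3 `COc1ccc(C(=O)/C=C\Nc2ccc(-c3nc4cc(OC)c(OC)c(OC)c4s3)cc2C)cc1F` gives 1800 nM, the lowest of the three numbers so far. Compound 1 `COc1ccc(C(=O)/C=C\Nc2ccc(-c3nc4cc(OC)c(OC)c(OC)c4s3)cc2C)cc1O` gives 15400 nM. Within the data shown here, compound 2 `COc1cc(C(=O)/C=C\Nc2ccc(-c3nc4cc(OC)c(OC)c(OC)c4s3)cc2C)cc([N+](=O)[O-])c1OC`, the only measured compound with a nitro group, gives 22000 nM. Compound 4 `COc1ccc(C(=O)/C=C\Nc2ccc(-c3nc4cc(OC)c(OC)c(OC)c4s3)cc2C)cc1[N+](=O)[O-]` has nitro in place of fluoro on an aromatic carbon, ortho to a methoxy group: nitro in place of fluoro on an aromatic carbon. Among the measured compounds shown here, the one measured step at this place, an 8.6-fold lower number from compound 1 to compound 3 (0.93 log units; beyond the scatter), came with fluoro in place of hydroxy, so a loss of fluoro may well raise the number by a similar size. Compound 2 at 22000 nM points the same way, though it is not a clean comparison. A higher number is expected in this assay, an estimated 4.4-fold higher number from compound 3 to compound 4 (0.65 log units; beyond the scatter). For compound 4 the estimated value is 8000 nM, with an expected range of 2500 nM to 25000 nM.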

Compound 4, half-maximal inhibitory concentration: 23400 nM
Compound 4: the middle estimate sits 2.9-fold (0.47 log units) below what was measured, and the stated range covers the measured number.
By their numbers in this assay, from the lowest: compound 3; then compounds 1, 2 and 4 (each within the scatter of the next).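

On the 3-fluoro-4-methoxyphenyl ring, fluoro now stands apart from the other groups seen at this place in this assay: a 13-fold higher number from compound 3 to compound 4 (1.11 log units; beyond the scatter) comes with nitro in place of fluoro, while a 1.5-fold higher number from compound 1 to compound 4 (0.18 log units; within the scatter) with nitro in place of hydroxy leaves those two groups unseparated. The step of a 1.1-fold higher number from compound 2 to compound 4 (0.03 log units; within the scatter) with hydrogen in place of methoxy shows that the further methoxy of compound 2 makes no readable difference among the nitro compounds.

As far as these compounds go, whether chloro, an amine or a trifluoromethyl group at this place would track fluoro or nitro stays open. No measurement available here speaks to why fluoro differs from nitro and hydroxy.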